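The compounds below may be only part of what the source reports. "The series", "measured", "known", "first", "only" and "open" are said of these compounds alone.

Compound 1 `C=C[C@@](C)(/C=C/c1ccc(OS(=O)(=O)c2ccc(C)cc2)cc1)CCC=C(C)C` gives > 52000 nM in a functional assay on HepG2 cells (Homo sapiens) for cytotoxicity, with a stated time of 72 h; on this read-out lower numbers stand for an effect already at smaller amounts and higher numbers for an effect only at larger amounts of compound.
Compound 2 `C=C[C@@](C)(/C=C/c1ccc(O)cc1)CC/C=C(\C)CO` gives > 52000 nM in this assay.
Compound 3 `C=C[C@@](C)(/C=C/c1ccc(O)c(/C=C/C(=O)c2ccccc2)c1)CCC=C(C)C` gives > 52000 nM in this assay.

Each of these three values is a limit of the assay rather than a measured number. For compound 1 the entry is such a limit. For compound 2 the entry is likewise a limit. For compound 3 the entry is again a limit, so no number for it is known. All three sit at the limit of > 52000 nM in this assay, at which 3 of the 3 values shown sit, and compound 3 therefore stands nowhere apart from the other two; nothing in these data ranks them against one another.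

Compound 4 `C=C[C@@](C)(/C=C/c1ccc(O)c(/C=C/C=C/c2ccccc2)c1)CCC=C(C)C` has not yet been measured. It differs from compound 3 in one place: 2-phenylethenyl in place of benzoyl on a double-bonded chain carbon bound to a double-bonded chain carbon. Within the data shown here, no step between two measured compounds is available, so there is no measured change to lean on. Given that compound 3 gives only a limit in this assay, the expectation is that compound 4 will also reach no measurable effect within the tested range, and the expected step that the limit leaves unreadable from compound 3 to compound 4 is none beyond the usual scatter. Compound 4 is accordingly estimated at 60000 nM, within a range from 20000 nM to 180000 nM, most likely reported again only as a limit.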

Compound 4, half-maximal effective concentration: > 52000 nM
Compound 4: a limit, no number; the forecaster's own chance of this, stated with the estimate: 80%; the middle value does not contradict the limit.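

Among these compounds, for compound 3 and compound 4 the entries in this assay are both limits, and no step between the two can be read. The compounds shown leave open whether any of them reaches a measurable effect in this assay, and how they would rank against one another, with every entry standing at the same limit: the limit of > 52000 nM in this assay, at which 4 of the 4 values shown sit.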